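The compounds below may be only part of what the source reports. "The series", "measured", "known", "first", "only" and "open" are said of these compounds alone.

Measured in a functional assay on MCF7 cells (Homo sapiens) for cytotoxicity, read by sulforhodamine B assay; a lower number here means a stronger inhibitor of growth, a higher number a weaker inhibitor of growth:
Compound 1 `CC1=CC[C@@H]([C@@](C)(O)CCCC(C)(C)NC(=S)NN)CC1`: 84200 nM
Compound 2 `CC1=CC[C@@H]([C@@](C)(O)CCCC(C)(C)NC(=S)N/N=C\c2ccccc2[N+](=O)[O-])CC1`: > 100000 nM, a limit

Compound 2 stands at a limit and has no number, with > 100000 nM as its only entry. Compound 3 `CC1=CC[C@@H]([C@@](C)(O)CCCC(C)(C)NC(=S)N/N=C\c2ccc(Cl)cc2)CC1` carries 4-chlorophenyl in place of 2-nitrophenyl on a carbon with a double bond to nitrogen. Among the compounds with values here, no measured step covers this exchange, so only a small gain in growth inhibition is expected, possibly none beyond the scatter. Within the data shown here, the only measured number is that of compound 1, 84200 nM, and the expectation stays close to it. The expected change is an at least 1.4-fold lower number from compound 2 to compound 3 (0.15 log units; that floor lies within the scatter). For compound 3 the estimated value is 70000 nM, with an expected range of 30000 nM to 100000 nM.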

Compound 3, concentration for total growth inhibition: 15800 nM
Compound 3: the middle estimate sits 4.4-fold (0.65 log units) above what was measured; the measured number lies below the stated range.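

In this assay, the carbon with a double bond to nitrogen turns out to be a place where the aryl group matters, with 4-chlorophenyl in place of 2-nitrophenyl giving an at least 6.3-fold lower number from compound 2 to compound 3 (0.80 log units; beyond the scatter). That size is only a floor because compound 2 stands at a limit: the limit of > 100000 nM in this assay, at which 1 of the 3 values shown sits. A ring-bearing group on the amide-type nitrogen need not cost growth inhibition, as its exchange for one nitrogen atom gives a 5.3-fold lower number from compound 1 to compound 3 (0.73 log units; beyond the scatter).

As far as these compounds go, whether the gain follows the entering chlorine or the leaving nitro group remains open. So does how a plain phenyl, 4-fluorophenyl or 2-chlorophenyl would behave at this carbon.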